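A few compounds are considered here, and "the series" means these few. Any claim that something is new, unique, unknown or untested is made for them only; others in the source may bear on it.

Compound 1 `C[C@@H](Cn1c(=O)[nH]/c(=N\c2ccc(Oc3cnccn3)cc2)n(Cc2ccc(Cl)cc2)c1=O)C(=O)O` and compound 2 `C[C@@H](Cn1c(=O)[nH]/c(=N\c2ccc(Oc3ccnc(F)c3)cc2)n(Cc2ccc(Cl)cc2)c1=O)C(=O)O` share one core and differ only in the aromatic ring carried on an oxygen. For the measured compounds named here, in an ADME assay on the whole organism (plasma, Rattus norvegicus) for protein binding, using cassette dosing, at a dose of 1 mg/kg (on this read-out higher numbers stand for a larger free fraction and lower numbers for a smaller free fraction), compound 1 gives 0.018 and compound 2 gives 0.013, so compound 2 stands within the scatter of the only other measured compound. Compound 3 `C[C@@H](Cn1c(=O)[nH]/c(=N\c2ccc(Oc3ccsn3)cc2)n(Cc2ccc(Cl)cc2)c1=O)C(=O)O` makes one further change: 1,2-thiazol-3-yl in place of 2-fluoropyridin-4-yl on an oxygen on an aromatic ring. In words, 1,2-thiazol-3-yl comes in place of 2-fluoropyridin-4-yl on an oxygen on an aromatic ring. Going by the values given here, the one measured step that bears on this swaps the ring at the same place, and a 1.4-fold lower number from compound 1 to compound 2 (0.14 log units; within the scatter) stays within the scatter. That is thin evidence, as no five-membered ring has been measured yet. The expected change is a 1.2-fold higher number from compound 2 to compound 3 (0.09 log units; within the scatter), and no move beyond the scatter is expected. For compound 3 the estimated value is 0.016, with an expected range from 0.008 to 0.032.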

Compound 3, unbound fraction in the Rattus norvegicus assay: 0.012
The estimate for compound 3 lay 1.3-fold (0.12 log units) above the measured number, within the range that was stated.
By their numbers in the Rattus norvegicus assay, from the lowest: compounds 3, 2 and 1 (each within the scatter of the next).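

With the first five-membered ring at this place, on an oxygen on an aromatic ring, the Rattus norvegicus assay still shows no move beyond the scatter: a 1.1-fold lower number from compound 2 to compound 3 (0.03 log units; within the scatter), and a 1.5-fold lower number from compound 1 to compound 3 (0.18 log units; within the scatter). Ring size and ring type, at least across these three compounds, therefore leave the free fraction unresolved, with all three values lying close together. The exchange of 2-fluoropyridin-4-yl for 1,2-thiazol-3-yl does separate the two compounds in a physicochemical assay for solubility, at pH 6.8 (a higher number here means a more soluble compound, a lower number a less soluble compound), where compound 2 gives 212 ug/mL and compound 3 gives 650 ug/mL, so that compound 3 is the more soluble: the measured solubility of compound 2, 212 ug/mL, and of compound 3, 650 ug/mL, a 3.1-fold higher number (0.49 log units; beyond the scatter)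

On these data alone, these compounds all carry an aromatic ring on this oxygen, so it stays open whether a ring bearing an amine, or an open alkyl chain, would shift the free fraction beyond the scatter. As far as these compounds go, it also stays open whether the difference in solubility would hold on a different core.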